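A few compounds are considered here, and "the series" means these few. Any claim that something is new, unique, unknown or untested is made for them only; others in the source may bear on it.

Of the compounds shown here, two sharing one core have been measured in a functional assay on HCT-116 cells (Homo sapiens) for inhibition, read by MTT assay, with a stated time of 48 h; on this read-out higher numbers stand for weaker inhibition and lower numbers for stronger inhibition. Compound 1, `COc1ccc(CNc2cc(OC)c(OC)c(OC)c2)cc1Br`, gives 48100 nM there. Compound 2, `C=C(C)C(=O)N(Cc1ccc(OC)c(O)c1)c1cc(OC)c(OC)c(OC)c1`, gives 200 nM, the lowest of the two numbers; its gap to compound 1 lies well beyond the usual scatter of repeated measurements, so compound 2 is clearly the stronger inhibitor of the pair. Compound 3, `COc1ccc(CN(C(=O)CBr)c2cc(OC)c(OC)c(OC)c2)cc1O`, has not yet been measured. It differs from compound 2 in a single place on the carbonyl carbon that also carries the amide-type nitrogen: bromomethyl in place of 1-methylethenyl on a carbonyl carbon. For the measured compounds named here, no pair of measured compounds separated by a change of this kind exists here, so the size of the step can only be estimated. The expectation is a step of a 1.3-fold lower number from compound 2 to compound 3 (0.12 log units; within the scatter) that stays within the scatter or leans slightly toward stronger inhibition. Compound 3 is therefore estimated to give 150 nM in this assay, with a range from 40 nM to 600 nM.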

Compound 3, half-maximal inhibitory concentration: 68 nM
Compound 3: the middle estimate sits 2.2-fold (0.34 log units) above what was measured, and the stated range covers the measured number.
By their numbers in this assay, from the lowest: compound 3; then compound 2; then compound 1.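

In this assay, for the compounds shown here, bromomethyl in place of 1-methylethenyl on the carbonyl carbon gives a 2.9-fold lower number from compound 2 to compound 3 (0.47 log units; beyond the scatter) as a modest step toward stronger inhibition, the first measured change at this position. Between these two compounds, the double bond of the 1-methylethenyl group is therefore not needed to reach a low number, and the position accepts a quite different group without losing inhibition. No measurement available here shows what lies behind this step.

From the compounds shown here alone, it remains open whether the bromine itself matters, since a plain methyl or a chloromethyl group on the same carbonyl carbon would show how much of the step depends on that atom. An isopropyl group would separate the double bond of 1-methylethenyl from its branched carbon shape, and a longer chain such as 2-bromoethyl would show whether the bromine tolerates being moved further out.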